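Nitro for Chloro in a Three-Compound Series

The compounds below may be only part of what the source reports. "The series", "measured", "known", "first", "only" and "open" are said of these compounds alone.

Compound 1 `COc1cccc(-c2nc3cc(Cl)ccc3[nH]2)c1Cl` and compound 3 `COc1cccc(-c2nc3cc([N+](=O)[O-])ccc3[nH]2)c1Cl` share a core and differ by nitro in place of chloro on an aromatic carbon. In an assay for inhibition of Alpha amylase (Homo sapiens), with a stated time of 10 min (on this read-out higher numbers stand for weaker inhibition and lower numbers for stronger inhibition), compound 1 gives 2780 nM, and compound 3 gives 2780 nM, so that no change at the digits printed from compound 1 to compound 3 (within the scatter). Compound 2 `COc1cc(Br)c(-c2nc3cc(Cl)ccc3[nH]2)cc1OC` differs from compound 1 in more than one place; the difference between the two cores is not broken down here. In this assay compound 2 gives 1730 nM, which lies within the scatter of compound 1 and of compound 3. Compound 4 `COc1cc(Br)c(-c2nc3cc([N+](=O)[O-])ccc3[nH]2)cc1OC` is not yet measured and arises from compound 2 by nitro in place of chloro on an aromatic carbon, the same change at the same place as that from compound 1 to compound 3. Because the earlier step read no change at the digits printed from compound 1 to compound 3 (within the scatter), a step of like size is expected, a 1.0-fold higher number from compound 2 to compound 4 (0.00 log units; within the scatter). Compound 4 is accordingly estimated at 1750 nM in this assay, with a range from 900 nM to 3500 nM.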

Compound 4, half-maximal inhibitory concentration: 1870 nM
Estimate against measurement, compound 4: 1.1-fold (0.03 log units) below; low and high end bracket the measured number.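

On the core of compound 2, nitro in place of chloro on an aromatic carbon gives a 1.1-fold higher number from compound 2 to compound 4 (0.03 log units; within the scatter). Among the compounds shown here, the swap reads alike on the two cores in this assay: the same change on two cores in this assay, no change at the digits printed (within the scatter) from compound 1 to compound 3 and a 1.1-fold higher number (0.03 log units; within the scatter) from compound 2 to compound 4, 1.1-fold (0.03 log units) apart, within the scatter of two such steps This shows that the swap can be carried between these two cores with the result staying within the scatter, but it rests on only two pairs at one place and does not show that the same would hold on any other core, nor does it explain the result.

The compounds shown leave open whether an amine or a carboxylic acid at this place would read like chloro and nitro. They also leave open how a longer chain there would read.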